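The source may report more compounds than this note shows. Statements on the series, on what has been measured and on what is new or still open speak of the compounds shown alone.

Compound 1, `Cc1nc(-c2cccnc2)sc1-c1nnc(-c2ccc(Br)cc2)o1`, gives > 100 ug/mL in an ADME assay on HeLa cells (Homo sapiens) for cytotoxicity, read by MTT assay; a lower number here means that less compound is tolerated, a higher number that more compound is tolerated; this is a limit of the assay rather than a number.
Compound 2, `Cc1nc(-c2cccnc2)sc1-c1nnc(-c2cccnc2)o1`, gives > 100 ug/mL in this assay; this too is a limit, not a number.
Compound 3, `COc1ccccc1-c1nnc(-c2sc(-c3cccnc3)nc2C)o1`, gives > 100 ug/mL in this assay; again only a limit is known.

All three measured compounds therefore sit at the same point: the limit of > 100 ug/mL in this assay, at which 3 of the 3 values shown sit. Compound 3 stands nowhere above or below its two partners. All that is known of it is that same limit. The steps among the measured compounds cannot be read: a step that the two limits leave unreadable from compound 1 to compound 2, a step that the two limits leave unreadable from compound 1 to compound 3 and a step that the two limits leave unreadable from compound 2 to compound 3 all run between two limits, so their size is hidden.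

Compound 4, `Cc1ccccc1-c1nnc(-c2sc(-c3cccnc3)nc2C)o1`, has not yet been tested in this assay. It differs from compound 3 at one place: methyl in place of methoxy on an aromatic carbon. The steps that touch the same position, from compound 1 or compound 2 to compound 3, were unreadable, so they give no direction to expect and no size beyond the scatter. The estimate for compound 4 in this assay is 200 ug/mL, within 70 ug/mL to 600 ug/mL, most likely reported again only as a limit. The step this estimate implies, a step that the limit leaves unreadable from compound 3 to compound 4, is expected to be invisible in the same way.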

Compound 4, half-maximal cytotoxic concentration: > 100 ug/mL
Compound 4: a limit, no number; the forecaster's own chance of this, stated with the estimate: 85%; the middle value does not contradict the limit.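

Compound 4 gives only a limit, so its steps from compound 1, compound 2 and compound 3 cannot be read, and all four compounds stand at one point: the limit of > 100 ug/mL in this assay, at which 4 of the 4 values shown sit.

Still open, from the compounds shown here alone, is where the real value of any of these four compounds lies in this assay, and whether exchanging these groups changes it at all.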